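The source may report more compounds than this note shows. Statements on the series, on what has been measured and on what is new or still open speak of the compounds shown alone.

Compound 1 `COc1ccc(NC(=O)COc2cc(C)nc3ccc(OC)cc23)cc1` stands highest of the two measured compounds in a physicochemical assay for solubility, in phosphate buffer, measured as kinetic solubility, with a stated time of 1 h, at pH 7.4 (on this read-out lower numbers stand for lower solubility and higher numbers for higher solubility), where compound 1 gives 108000 nM. Compound 2 `COc1ccc2nc(C)cc(OCC(=O)Nc3cc(OC)c(OC)c(OC)c3)c2c1` is its only comparator; in this assay compound 2 gives 34000 nM, a lower number that lies beyond the scatter. Compound 3 `COc1ccc2nc(C)cc(OCC(=O)Nc3ccncn3)c2c1` has not yet been measured. It differs from compound 1 in one place: pyrimidin-4-yl in place of 4-methoxyphenyl on an amide-type nitrogen. Among the measured compounds shown here, no measured pair shows such a change, so the step is expected to be small, an increase from compound 1 that stays within the scatter, as a 1.4-fold higher number from compound 1 to compound 3 (0.14 log units; within the scatter). On that basis compound 3 is estimated at 150000 nM, with a range from 60000 nM to 400000 nM.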

Compound 3, solubility: 27500 nM
The estimate for compound 3 lay 5.5-fold (0.74 log units) above the measured number; the measured number lies below the stated range.
By their numbers in this assay, from the lowest: compounds 3 and 2 (each within the scatter of the next); then compound 1.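

At the amide-type nitrogen, the choice of ring is not neutral in this assay: pyrimidin-4-yl in place of 4-methoxyphenyl gives a 3.9-fold lower number from compound 1 to compound 3 (0.59 log units; beyond the scatter), a modest step beyond the scatter. The entering group carries 2 hydrogen-bond acceptors where the leaving group carries 1, yet the number falls. Nothing available accounts for this fall. As far as these compounds go, whether a pyridin-3-yl ring or a phenyl ring bearing a morpholine would follow the same direction at this place remains open. This single step cannot separate the loss of the methoxy from the entry of the ring nitrogens.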